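A few compounds are considered here, and "the series" means these few. Any claim that something is new, unique, unknown or untested is made for them only; others in the source may bear on it.

Compound 1 `O=C(NCc1ccc(S(=O)(=O)c2ccc(F)c(F)c2)cc1)c1cc2cnccc2[nH]1` gives 10 nM in an assay for inhibition of Nicotinamide phosphoribosyltransferase (Homo sapiens), read by mass spectrometry, with stated times of 15 min and 30 min (a lower number here means a stronger inhibitor, a higher number a weaker inhibitor), which puts it second highest of the three numbers measured: compound 2 `O=C(NCc1ccc(S(=O)(=O)N2CCCCC2)cc1)c1cnc2nccn2c1` gives 3 nM, and compound 3 `O=C(NCc1ccc(S(=O)(=O)N2CCCCC2)cc1)c1cc2cnccc2o1` gives 140 nM. Within the data shown here, the only step among measured pairs is a 47-fold higher number from compound 2 to compound 3 (1.67 log units; beyond the scatter), a change on the carbonyl carbon that does not touch the sulfonyl side. Compound 4 `O=C(NCc1ccc(S(=O)(=O)c2cccc(F)c2)cc1)c1cc2cnccc2[nH]1` differs from compound 1 in the sulfonyl-linked ring: hydrogen in place of fluoro on an aromatic carbon, 3,4-difluorophenyl becoming 3-fluorophenyl. Among the measured compounds shown here, no measured step bears on this change, so the expectation rests only on the value of compound 1 and on the change being small. The step from compound 1 to compound 4 is therefore expected to be a 1.5-fold higher number from compound 1 to compound 4 (0.18 log units; within the scatter), not beyond the scatter. Compound 4 is estimated at 15 nM, in the range 5 nM to 45 nM.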

Compound 4, half-maximal inhibitory concentration: 5 nM
Compound 4: the middle estimate sits 3.0-fold (0.48 log units) above what was measured; the measured number falls inside the stated range.
By their numbers in this assay, from the lowest: compounds 2, 4 and 1 (each within the scatter of the next, the first and the last beyond it); then compound 3.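

In this assay, hydrogen in place of fluoro on the aromatic carbon para to a large group gives a 2.0-fold lower number from compound 1 to compound 4 (0.30 log units; within the scatter), so this change of 3,4-difluorophenyl to 3-fluorophenyl leaves the two compounds indistinguishable. This is the only step shown on the sulfonyl-linked ring, and the fluoro at this position is not needed to keep compound 4 level with compound 1. No measurement at hand offers a reason for this result.

As far as these compounds go, what a chloro or methoxy group on this carbon would give remains open. So does the effect of an unsubstituted phenyl ring.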